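The source may report more compounds than this note shows. Statements on the series, on what has been measured and on what is new or still open speak of the compounds shown alone.

Two compounds share one core and differ only in the group carried on the amide side of the molecule. Compound 1 `O=C(CCc1cccc2c1B(O)OC2)Nc1cccc(I)c1` carries an iodo group, and in a functional assay on SK-OV-3 cells (Homo sapiens) for antiproliferative activity, read by MTT assay, with a stated time of 72 h (a higher number here means a weaker inhibitor, a lower number a stronger inhibitor), compound 1 gives 630 nM. Compound 2 `O=C(CCc1cccc2c1B(O)OC2)Nc1cccc(-c2ccc(Cl)cc2)c1` carries a 4-chlorophenyl group instead, and in this assay compound 2 gives 220 nM. Among the measured compounds shown here, the single measured step, a 2.9-fold lower number from compound 1 to compound 2 (0.46 log units; beyond the scatter), is a modest gain. For the measured compounds named here, of the two measured numbers, compound 2 has the lower one and so the stronger inhibition, with compound 1 as its only neighbour.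

Compound 3 `O=C(CCc1cccc2c1B(O)OC2)Nc1cccc(-c2cccc(C(F)(F)F)c2)c1` is the next variation: 3-(trifluoromethyl)phenyl in place of 4-chlorophenyl on an aromatic carbon. Going by the values given here, no measured step swaps one substituted phenyl for another; the one step known, a 2.9-fold lower number from compound 1 to compound 2 (0.46 log units; beyond the scatter), concerns a halogen giving way to a whole ring, a different kind of change. Nothing shown therefore points firmly either way, and a small step, within the usual scatter or barely beyond it, is the plainest expectation in this assay. For compound 3 the estimated value is 300 nM, with a range from 120 nM to 750 nM. This estimate means an expected step of a 1.4-fold higher number from compound 2 to compound 3 (0.13 log units; within the scatter).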

Compound 3, half-maximal inhibitory concentration: 390 nM
For compound 3 the middle estimate is 1.3-fold (0.11 log units) below the measured one; low and high end bracket the measured number.
By their numbers in this assay, from the lowest: compounds 2, 3 and 1 (each within the scatter of the next, the first and the last beyond it).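

In this assay, exchanging 4-chlorophenyl for 3-(trifluoromethyl)phenyl gives a 1.8-fold higher number from compound 2 to compound 3 (0.25 log units; within the scatter), so this position accepts these two different substituted phenyl rings without a change that can be told from the scatter. The comparison with iodo adds a caution: the new ring gives a 1.6-fold lower number from compound 1 to compound 3 (0.21 log units; within the scatter), whereas 4-chlorophenyl gave a 2.9-fold lower number from compound 1 to compound 2 (0.46 log units; beyond the scatter), so placing a substituted phenyl ring here does not always give a difference from iodo that lies beyond the scatter. Nothing available explains these results in terms of a measured property of the groups.

The substituent and its place on the ring both differ between compound 2 and compound 3, so this step cannot be assigned to either one alone, and 3-chlorophenyl would be the group needed to separate them. Also open, going by these compounds, is how this assay responds when the phenyl ring carries an amine or a carboxylic acid, or when a pyridine ring takes its place.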